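Swapping a Difluorophenyl Ring for an Aminophenyl Ring

This account rests on a few compounds, and the source may have more. Where it says the series, first, only, none or still open, it means among the compounds named here.

Of the compounds shown here, three built on one shared core have been measured in a functional assay on HL-60 cells (Homo sapiens) for cytotoxicity, read by CellTiter-Blue, with a stated time of 48 h; on this read-out higher numbers stand for weaker inhibition and lower numbers for stronger inhibition. Compound 1 `CCOC(=O)CC1C(C(=O)OC)=C(N)Oc2ccc(-c3cc(OC)cc(OC)c3)cc21` gives 10800 nM. Compound 2 `CCCCOC(=O)CC1C(C(=O)OCCCC)=C(N)Oc2ccc(-c3cc(OC)cc(OC)c3)cc21` gives 32000 nM. Compound 3 `CCOC(=O)CC1C(C(=O)OCC)=C(N)Oc2ccc(-c3ccc(F)cc3F)cc21` gives 76600 nM, the highest number of the three and therefore the weakest inhibition; its gaps to compound 2 and to compound 1 both lie beyond the scatter, so it stands clearly apart from them.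

Compound 4 `CCOC(=O)CC1C(C(=O)OCC)=C(N)Oc2ccc(-c3ccc(N)cc3)cc21` has not yet been measured. It differs from compound 3 in one place: 4-aminophenyl in place of 2,4-difluorophenyl on an aromatic carbon. For the measured compounds named here, no pair of measured compounds differing in only one place is available, so the size and direction of this step cannot be read off earlier data. Compounds 1 and 2 carry a different ring in this place and give lower numbers than compound 3, but they also differ from compound 3 elsewhere, so they do not settle the matter. A moderate lowering is expected, a 2.6-fold lower number from compound 3 to compound 4 (0.41 log units; beyond the scatter). Compound 4 is estimated at 30000 nM, within a range from 8000 nM to 120000 nM.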

Compound 4, half-maximal inhibitory concentration: 22300 nM
The estimate for compound 4 lay 1.3-fold (0.13 log units) above the measured number; the measured number falls inside the stated range.
By their numbers in this assay, from the lowest: compound 1; then compounds 4 and 2 (each within the scatter of the next); then compound 3.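

For the compounds shown here, this is the first pair of compounds here that differ in only one place, so the effect of the group on this aromatic carbon can now be read directly. In this assay, 4-aminophenyl in place of 2,4-difluorophenyl gives a 3.4-fold lower number from compound 3 to compound 4 (0.54 log units; beyond the scatter), which shows that this position responds to a change of its ring substituents while the rest of the molecule stays the same. No measured evidence bears on why the number falls.

The change removes two fluorines and adds an amino group in one step, so the compounds shown cannot separate the two, and an unsubstituted phenyl ring in this place would help to do so. From the compounds shown here alone, whether the same step holds with other ester chains, such as the butyl esters of compound 2, also remains open.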